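A few compounds are considered here, and "the series" means these few. Any claim that something is new, unique, unknown or untested is made for them only; others in the source may bear on it.

Working notes on the series, all read in a functional assay on IMR-32 cells (Homo sapiens) for antiproliferative activity, read by sulforhodamine B assay, with a stated time of 48 h; on this read-out higher numbers stand for weaker inhibition of growth and lower numbers for stronger inhibition of growth. Compound 1 (`Cc1ccc(-c2cn(CCCN3C(=O)COc4ccccc43)nn2)cc1`) gives 4400 nM, compound 2 (`CCCCCc1ccc(-c2cn(CCCN3C(=O)COc4ccccc43)nn2)cc1`) gives 43500 nM, and compound 3 (`O=C1COc2ccccc2N1CCCn1cc(-c2ccccn2)nn1`) gives 2000 nM. Compound 3 therefore holds the lowest of the three numbers, with compound 1 nearest and compound 2 furthest.

The next change leads to compound 4 (`O=C1COc2ccccc2N1CCCn1cc(CCCCl)nn1`): 3-chloropropyl in place of pyridin-2-yl on an aromatic carbon. This places 3-chloropropyl in place of pyridin-2-yl on an aromatic carbon of a five-membered aromatic ring with 3 nitrogen.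

Going by the values given here, two measured steps bear on it, both modest and beyond the scatter. Among the compounds with values here, the exchange of 4-methylphenyl for pyridin-2-yl on an aromatic carbon gave a 2.2-fold lower number from compound 1 to compound 3 (0.34 log units; beyond the scatter), so the one other group measured in place of pyridin-2-yl, on compound 1, reads higher. Butyl in place of hydrogen on a saturated chain carbon gave a 9.9-fold higher number from compound 1 to compound 2 (1.00 log units; beyond the scatter), so the added chain on compound 2 also went upward. Within the data shown here, no measured compound has a chlorine or lacks a ring at this carbon, so the evidence is indirect.

A modest upward step is expected, estimated as a 2.5-fold higher number from compound 3 to compound 4 (0.40 log units; beyond the scatter). For compound 4 the expected value is 5000 nM, with an estimated range of 1500 nM to 18000 nM.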

Compound 4, concentration for 50% growth inhibition: 200 nM
For compound 4 the middle estimate is 25-fold (1.40 log units) above the measured one; measured number outside the range, below it.
By their numbers in this assay, from the lowest: compound 4; then compound 3; then compound 1; then compound 2.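

In this assay, the step of a 10-fold lower number from compound 3 to compound 4 (1.00 log units; beyond the scatter) and the larger step of a 22-fold lower number from compound 1 to compound 4 (1.34 log units; beyond the scatter) show that an aromatic ring is not needed on this aromatic carbon of the five-membered ring for a low number: the open 3-chloropropyl chain, with no ring, gives the lowest number of the four compounds. Going by these compounds alone, the earlier compounds carried only aromatic rings at this carbon, and the one chain change among them, butyl added to the saturated chain carbon of compound 1, moved the number upward; that step lies in a different place and does not carry over to a chain set directly on this carbon. No measurement shown gives a reason for the drop on going to 3-chloropropyl.

The compounds shown do not separate the part played by the chlorine from that of the open chain, and a plain propyl group or a 3-aminopropyl group at this carbon would make that comparison. As far as these compounds go, how far the chain length matters also remains open, which a longer chain such as 4-chlorobutyl would address.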